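Swapping the amide substituent toward an isopropyl analogue

The source may report more compounds than this note shows. Statements on the series, on what has been measured and on what is new or still open speak of the compounds shown alone.

Compound 1 `CC(C)N1C(=O)COc2ccc(-c3cnc(Cl)c(NS(=O)(=O)c4ccc(F)cc4)c3)cc21` gives 5380 nM in a functional assay on HeLa cells (Homo sapiens) for antiproliferative activity, read by MTT assay, with a stated time of 72 h; a higher number here means a weaker inhibitor, a lower number a stronger inhibitor.
Compound 2 `O=C1COc2ccc(-c3cnc(Cl)c(NS(=O)(=O)c4ccc(F)cc4)c3)cc2N1c1ccc(Cl)cc1` reaches only the limit of this assay, > 40000 nM.
Compound 3 `COc1ncc(-c2ccc3c(c2)N(c2ccc(Cl)cc2)C(=O)CO3)cc1NS(=O)(=O)c1ccc(F)cc1` gives 4830 nM.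

The three measured compounds share one core and differ at two places. Compound 2 sits at the limit (the limit of > 40000 nM in this assay, at which 1 of the 3 values shown sits), so the steps leading away from it are only bounds. From compound 2 to compound 1 the change is isopropyl in place of 4-chlorophenyl on an amide-type nitrogen in a ring, and the step is an at least 7.4-fold lower number from compound 2 to compound 1 (0.87 log units; beyond the scatter). The cores of compound 2 and compound 3 differ by methoxy in place of chloro on an aromatic carbon, with a step of an at least 8.2-fold lower number from compound 2 to compound 3 (0.91 log units; beyond the scatter). Compound 1 and compound 3 lie within the scatter of each other.

Compound 4 `COc1ncc(-c2ccc3c(c2)N(C(C)C)C(=O)CO3)cc1NS(=O)(=O)c1ccc(F)cc1` is not yet measured. It differs from compound 3 by isopropyl in place of 4-chlorophenyl on an amide-type nitrogen in a ring, the same change made from compound 2 to compound 1, made on the methoxy core. Because that earlier step was an at least 7.4-fold lower number from compound 2 to compound 1 (0.87 log units; beyond the scatter), a step of a 2.4-fold lower number from compound 3 to compound 4 (0.38 log units; beyond the scatter) is expected here, though the earlier step is only a bound and the methoxy core may respond differently. Compound 4 is therefore estimated at 2000 nM, with an expected range from 500 nM to 6000 nM.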

Compound 4, half-maximal inhibitory concentration: 2790 nM
For compound 4 the middle estimate is 1.4-fold (0.14 log units) below the measured one; the measured number falls inside the stated range.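

In this assay, isopropyl in place of 4-chlorophenyl on the methoxy core gives a 1.7-fold lower number from compound 3 to compound 4 (0.24 log units; within the scatter), so the large gain seen on the chloro core does not carry over at the same size: the same change on two cores in this assay, an at least 7.4-fold lower number (0.87 log units; beyond the scatter) from compound 2 to compound 1 and a 1.7-fold lower number (0.24 log units; within the scatter) from compound 3 to compound 4, at least 4.2-fold (0.63 log units) apart, beyond the scatter of two such steps. Read the other way, methoxy in place of chloro gives a 1.9-fold lower number from compound 1 to compound 4 (0.29 log units; within the scatter) when isopropyl is present, and this too stands apart from the earlier step on the core carrying 4-chlorophenyl: the same change on two cores in this assay, an at least 8.2-fold lower number (0.91 log units; beyond the scatter) from compound 2 to compound 3 and a 1.9-fold lower number (0.29 log units; within the scatter) from compound 1 to compound 4, at least 4.2-fold (0.63 log units) apart, beyond the scatter of two such steps. Both earlier steps start from compound 2, whose > 40000 nM is a limit and not a number, so the data show that the two changes do not simply add up but cannot say how far they fall short: the limit of > 40000 nM in this assay, at which 1 of the 4 values shown sits.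

Going by these compounds, these four compounds cover only two substituents at each of the two places, so whether the pattern extends to any other core remains open. Also open, on these data alone, is how an amine, a carboxylic acid or a longer chain on the amide-type nitrogen would behave.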